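Dropping the Methoxy Group from Compound 2

The source may hold more compounds than are shown below. What is called first, only, known or untested is meant among the compounds shown, and "the series" means these compounds.

Of the compounds shown here, two built on a shared core have been measured in a functional assay on MCF7 cells (Homo sapiens) for antiproliferative activity, read by MTT assay, with a stated time of 48 h; on this read-out higher numbers stand for weaker inhibition and lower numbers for stronger inhibition. Compound 1 `O=C(/C=C/c1ccccc1)Nc1cc2c(Nc3ccc(Cl)c(Cl)c3)ncnc2s1` gives 15300 nM, while compound 2 `COc1ccc(/C=C/C(=O)Nc2cc3c(Nc4cc(Cl)cc(Cl)c4)ncnc3s2)cc1` gives 75600 nM. Compound 2 thus holds the higher of the two numbers, and the gap between them lies beyond the usual scatter. Compound 3 `O=C(/C=C/c1ccccc1)Nc1cc2c(Nc3cc(Cl)cc(Cl)c3)ncnc2s1` comes from compound 2 through a single change: hydrogen in place of methoxy on an aromatic carbon. Going by the values given here, no measured pair shows this change on its own, so any forecast remains uncertain. Compound 3 shares its 2-phenylethenyl with compound 1, which gives 15300 nM, and this points to a moderate fall in the number. The expected change is a 2.4-fold lower number from compound 2 to compound 3 (0.37 log units; beyond the scatter), towards stronger inhibition. Compound 3 is estimated at 32000 nM, with an expected range of 11000 nM to 80000 nM.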

Compound 3, half-maximal inhibitory concentration: 5800 nM
Compound 3: the middle estimate sits 5.5-fold (0.74 log units) above what was measured, and the stated range ends above it.
By their numbers in this assay, from the lowest: compound 3; then compound 1; then compound 2.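

Compound 3 separates the two changes that were tangled together between compound 1 and compound 2. In this assay, hydrogen in place of methoxy, para to a large group, gives a 13-fold lower number from compound 2 to compound 3 (1.12 log units; beyond the scatter), a large step that shows this position strongly affects the result when 3,5-dichlorophenyl is present, while 3,5-dichlorophenyl in place of 3,4-dichlorophenyl gives a 2.6-fold lower number from compound 1 to compound 3 (0.42 log units; beyond the scatter), a modest step with 2-phenylethenyl held fixed. Nothing available explains either step.

From the compounds shown here alone, it remains open how other groups at this position, such as fluorine, a hydroxyl or a dimethylamino group, would compare with hydrogen and methoxy. Going by these compounds, it is also open whether the methoxy step would keep its size with 3,4-dichlorophenyl on the nitrogen.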